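Swapping the para substituent on a benzisoxazole-series kinase inhibitor

A few compounds are considered here, and "the series" means these few. Any claim that something is new, unique, unknown or untested is made for them only; others in the source may bear on it.

Measured compounds:
- Compound 1, `CN(C)C(=O)/C=C/c1ccc2noc(-c3ccccc3)c2c1`: in an assay for inhibition of inositol hexakisphosphate kinase 3 (Homo sapiens), read by colorimetric assay, coupled enzyme assay and malachite green, with a stated time of 120 min, in the presence of a further agent that is not named here (on this read-out higher numbers stand for weaker inhibition and lower numbers for stronger inhibition), compound 1 gives only a limit, > 100000 nM.
- Compound 2, `O=C(O)/C=C/c1ccc2noc(-c3ccc(OC(F)(F)F)cc3)c2c1`: in this assay compound 2 gives 8370 nM.

Of the two results shown, compound 2 supplies the only actual number. The result for compound 1 is a limit of the assay and not a number, which is also what the limit of > 100000 nM in this assay, at which 1 of the 2 values shown sits, records. Compound 2 therefore stands alone as the single measured point from which the next step is taken.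

The unmeasured compound 3, `O=C(O)/C=C/c1ccc2noc(-c3ccc(-c4ccccc4)cc3)c2c1`, keeps the shared core and the acrylic acid of compound 2 and changes one group: phenyl in place of trifluoromethoxy on an aromatic carbon, para to a large group.

Going by the values given here, no measured pair of this kind exists here, so the size of the step is uncertain. The step from compound 2 to compound 3 is expected to be small, a 1.4-fold lower number from compound 2 to compound 3 (0.14 log units; within the scatter), lying within or close to the usual scatter. On that basis compound 3 is estimated at 6000 nM in this assay, with a range from 1500 nM to 25000 nM.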

Compound 3, half-maximal inhibitory concentration: 200 nM
Beside the measured number, compound 3's estimate is 30-fold (1.48 log units) above it; the measured number lies below the stated range.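

Replacing trifluoromethoxy with phenyl on an aromatic carbon, para to a large group, gives in this assay a 42-fold lower number from compound 2 to compound 3 (1.62 log units; beyond the scatter), a large step that lies beyond the scatter. Going by these compounds alone, this is the first change made in one place only, with the shared core and the acrylic acid held constant, so it shows that inhibition is highly sensitive to the group at this position. The phenyl group brings a six-membered aromatic ring and no hydrogen-bond acceptor, whereas the trifluoromethoxy group has no ring and one hydrogen-bond acceptor, but this single pair cannot show which of these differences matters.

Nothing measured here explains why this swap has so large an effect. As far as these compounds go, it remains open whether an aromatic ring is needed at this position, which a cyclohexyl group, a pyridine ring or a butyl chain could help to test, and whether phenyl would give the same gain if the carboxylic acid were replaced by a primary amide.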